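This account rests on a few compounds, and the source may have more. Where it says the series, first, only, none or still open, it means among the compounds named here.

In a functional assay with Oryctolagus cuniculus as the target (a lower number here means a stronger inhibitor, a higher number a weaker inhibitor), compound 1 `CNC(=N)Nc1nc(-c2ccc(OC)cc2)c(-c2ccc(OC)cc2)s1` gives 62 nM and compound 3 `COc1ccc(-c2nc(CNC(C)=O)sc2-c2ccc(OC)cc2)cc1` gives 15 nM as the lowest number of the set. Compound 2 `COc1ccc(-c2nc(/N=C(\N)[N+]3(C)CCCCC3)sc2-c2ccc(OC)cc2)cc1` reads > 1000 nM as a limit of the assay and not a number.

Compound 4 `COc1ccc(-c2nc(CNC(=O)N3CCOCC3)sc2-c2ccc(OC)cc2)cc1` is still unmeasured. Its difference from the acetamidomethyl compound, morpholin-4-yl in place of methyl on a carbonyl carbon in full, is morpholin-4-yl in place of methyl on a carbonyl carbon, turning acetamidomethyl into (((morpholin-4-yl)carbonyl)amino)methyl.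

For the measured compounds named here, no measured step makes this exact change, so the guidance is indirect. Going by the values given here, all the measured steps swap the whole group on the shared core: a 4.1-fold lower number from compound 1 to compound 3 (0.62 log units; beyond the scatter) is modest, while an at least 16-fold higher number from compound 1 to compound 2 (1.20 log units; beyond the scatter) and an at least 66-fold lower number from compound 2 to compound 3 (1.82 log units; beyond the scatter) are large. Compound 2, which carries the largest group of the three and also a six-membered ring, sits on the weak side of both large steps. That single case suggests a rise rather than a fall, but probably a smaller one, since compound 4 keeps the amide-type nitrogen of compound 3.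

The expected change in this assay is therefore a moderate rise, with a 2.7-fold higher number from compound 3 to compound 4 (0.43 log units; beyond the scatter) as the estimated step. Compound 4 is estimated at 40 nM with an expected range from 10 nM to 200 nM on this reasoning.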

Compound 4, half-maximal inhibitory concentration: 660 nM
Compound 4: the middle estimate sits 17-fold (1.22 log units) below what was measured; the whole stated range lies below it.
By their numbers in this assay, from the lowest: compound 3; then compound 1; then compound 4. At a limit, above all of these: compound 2.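

In this assay, for the compounds shown here, the earlier steps swapped the whole group on the shared core, whereas this one changes only what sits on the carbonyl carbon, and morpholin-4-yl in place of methyl gives a large rise, with a 44-fold higher number from compound 3 to compound 4 (1.64 log units; beyond the scatter). Keeping the amide-type nitrogen therefore does not keep the number low, and the change also takes the compound past the group on compound 1, with an 11-fold higher number from compound 1 to compound 4 (1.03 log units; beyond the scatter). The remaining step gives an at least 1.5-fold lower number from compound 2 to compound 4 (0.18 log units; that floor lies within the scatter) and so allows no statement of order for that pair. Compound 2 stands at a limit of the assay and not a number: the limit of > 1000 nM in this assay, at which 1 of the 4 values shown sits.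

Only methyl and morpholin-4-yl are shown on this carbonyl carbon, so it remains open how the number moves between them. Ethyl, dimethylamino or piperidin-1-yl there could show whether the ring or its oxygen goes with the rise.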